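A few compounds are considered here, and "the series" means these few. Any claim that something is new, unique, unknown or untested is made for them only; others in the source may bear on it.

Measured compounds:
compound 1, `Nc1cc(N)c2nc(-c3ccccc3)c(Oc3ccc(Cl)c(Cl)c3)nc2c1`: 36300 nM
compound 2, `Nc1cc(N)c2nc(-c3ccccc3)c(Oc3ccc(F)cc3)nc2c1`: 36300 nM
compound 3, `COc1cc(CNc2nc3cc(N)cc(N)c3nc2-c2ccccc2)cc(OC)c1OC`: 21900 nM

These three compounds share one core and were tested in a functional assay on NCI/ADR-RES cells (Homo sapiens) for inhibition, read by sulforhodamine B assay, with a stated time of 48 h; on this read-out lower numbers stand for stronger inhibition of growth and higher numbers for weaker inhibition of growth. Compound 1 gives 36300 nM, level with compound 2 at the digits shown, and together these two stand as the highest of the three numbers; compound 3 gives a number that is lower, though by an amount within the scatter, so no ranking between compound 1 and compound 3 can be claimed.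

Compound 4, `Nc1cc(N)c2nc(-c3ccccc3)c(Sc3ccc(Cl)c(Cl)c3)nc2c1`, has not yet been measured. It differs from compound 1 in one place: (3,4-dichlorophenyl)sulfanyl in place of 3,4-dichlorophenoxy on an aromatic carbon.

Among the compounds with values here, the only measured step with a single change is no change at the digits printed from compound 1 to compound 2 (within the scatter), and it swaps the aryl group on the oxygen rather than the linking atom itself, so it does not directly bear on an oxygen-to-sulfur change. Within the data shown here, with no measured step touching the linker, and the one measured swap in this region producing no change, compound 4 is expected to show no step beyond the scatter, a 1.0-fold lower number from compound 1 to compound 4 (0.00 log units; within the scatter).

Compound 4 is therefore estimated at 36000 nM in this assay, within a range of 15000 nM to 85000 nM.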

Compound 4, concentration for total growth inhibition: 60300 nM
Beside the measured number, compound 4's estimate is 1.7-fold (0.22 log units) below it; low and high end bracket the measured number.
By their numbers in this assay, from the lowest: compounds 3, 1, 2 and 4 (each within the scatter of the next, the first and the last beyond it).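

In this assay, within the data shown here, the linking atom at this position changes for the first time: sulfur takes the place of oxygen while the 3,4-dichlorophenyl group stays, and this gives a 1.7-fold higher number from compound 1 to compound 4 (0.22 log units; within the scatter) so no effect of the swap can be claimed. Changing the linking atom and the groups on the aryl ring together gives a 1.7-fold higher number from compound 2 to compound 4 (0.22 log units; within the scatter) so this larger change also stays inside the normal spread of repeated measurements. No supporting measurement explains these numbers.

The compounds shown leave open what a sulfonyl link, or a carboxylic acid in place of the aryl group, would do at this position. They also leave open whether sulfur for oxygen would read the same with the 4-fluorophenyl group.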